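Swapping the aryl group of a dibenzoylhydrazine ecdysone agonist

The compounds below may be only part of what the source reports. "The series", "measured", "known", "first", "only" and "open" are said of these compounds alone.

Compound 1 `CC(C)(C)N(NC(=O)c1ccccc1Br)C(=O)c1ccccc1Cl`: 316 nM
Compound 2 `CC(C)(C)N(NC(=O)c1cccc(Cl)c1)C(=O)c1ccccc1Cl`: 155 nM
Compound 3 `CC(C)(C)N(NC(=O)c1ccc(F)cc1)C(=O)c1ccccc1Cl`: 389 nM

In an assay on cells for agonist activity at ecdysone receptor (Bombyx mori), read by a luciferase reporter, with a stated time of 24 h (a higher number here means that more compound is needed for the effect, a lower number that less compound is needed), compound 1 stands second highest of the three numbers, with compound 3 nearest and compound 2 furthest away. Compound 4 `COc1ccc(C(=O)NN(C(=O)c2ccccc2Cl)C(C)(C)C)cc1` has not yet been measured. It differs from compound 1 by 4-methoxyphenyl in place of 2-bromophenyl on a carbonyl carbon. Two measured steps replace the same 2-bromophenyl on compound 1: a 2.0-fold lower number from compound 1 to compound 2 (0.31 log units; beyond the scatter) and a 1.2-fold higher number from compound 1 to compound 3 (0.09 log units; within the scatter). The 4-fluorophenyl change is the closer analogue of the 4-methoxyphenyl change, and it stayed within the scatter, so compound 4 is expected to lie near compound 1, with a 1.3-fold higher number from compound 1 to compound 4 (0.10 log units; within the scatter) and a wide range allowed. The estimate for compound 4 is 400 nM, between 150 nM and 1100 nM.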

Compound 4, half-maximal effective concentration: 51.3 nM
Compound 4: middle estimate off by 7.8-fold (0.89 log units), on the high side; the measured number lies below the stated range.
By their numbers in this assay, from the lowest: compound 4; then compound 2; then compounds 1 and 3 (each within the scatter of the next).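

In this assay the 4-methoxyphenyl group stands apart from the other aryl groups on this carbonyl carbon, with a 6.2-fold lower number from compound 1 to compound 4 (0.79 log units; beyond the scatter) and a 3.0-fold lower number from compound 2 to compound 4 (0.48 log units; beyond the scatter) pointing the same way. Exchanging only the substituent on the aromatic carbon matters as well: methoxy in place of fluoro gives a 7.6-fold lower number from compound 3 to compound 4 (0.88 log units; beyond the scatter) and so shows that the near silence of the 4-fluorophenyl change did not extend to every group on that ring.

Going by these compounds, whether an ethoxy group, an amine or a carboxylic acid in place of the methoxy would lower the number further remains open. The data shown offer no measurement that explains these steps.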